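Inverting one ring stereocentre in a biphenyl-ether glycoside series

The source may report more compounds than this note shows. Statements on the series, on what has been measured and on what is new or still open speak of the compounds shown alone.

The series shares a sugar-like core carrying a biphenyloxy methyl group and two free hydroxyls. Compound 1, `CO[C@H]1O[C@H](COc2ccc(-c3ccccc3)cc2)[C@@H](O)[C@H](O)[C@H]1Oc1ccccc1`, gives 33000 nM in a functional assay on HeLa cells (Homo sapiens) for cytotoxicity, read by MTT assay, with a stated time of 48 h; a higher number here means that more compound is needed for the effect, a lower number that less compound is needed. Compound 2, `CO[C@@H]1O[C@H](COc2ccc(-c3ccccc3)cc2)[C@@H](O)[C@H](O)[C@H]1Oc1cccc(C(C)C)c1`, gives 32000 nM in this assay. Compound 2 holds the lower of the two numbers, but compound 1 sits within the scatter of it, so the two values are indistinguishable. Compound 3, `CO[C@H]1O[C@H](COc2ccc(-c3ccccc3)cc2)[C@@H](O)[C@H](O)[C@H]1Oc1cccc(C(C)C)c1`, is not yet measured. The change from compound 2 to compound 3 is the two compounds have the same atoms and bonds and differ only in configuration as drawn: 1 of 5 stereo elements differ; a stereocentre at a saturated ring carbon is drawn R in compound 2 and S in compound 3. Within the data shown here, no step between two measured compounds is known in this set, so a single configurational change has no precedent here. With both measured values near each other, the step from compound 2 to compound 3 is expected to be no change at the digits printed from compound 2 to compound 3 (within the scatter), that is, nothing beyond the scatter. Compound 3 is therefore estimated at 32000 nM, within 16000 nM to 64000 nM.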

Compound 3, half-maximal effective concentration: 35000 nM
Beside the measured number, compound 3's estimate is 1.1-fold (0.04 log units) below it; the range from low to high includes it.
By their numbers in this assay, from the lowest: compounds 2, 1 and 3 (each within the scatter of the next).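

Inverting the stereocentre at a saturated ring carbon, drawn R in compound 2 and S in compound 3, gives a 1.1-fold higher number from compound 2 to compound 3 (0.04 log units; within the scatter) in this assay, the first configurational step in this set and one that cannot be told from the scatter. The comparison isolates configuration alone: the fact that compounds 2 and 3 differ only in the configuration as drawn. Isopropyl in place of hydrogen on an aromatic carbon, read at the configuration shared by compound 1 and compound 3, gives a 1.1-fold higher number from compound 1 to compound 3 (0.03 log units; within the scatter), so this substituent step also stays inside the scatter.

The compounds shown leave open whether this stereocentre would matter with an amine or a carboxylic acid in place of the isopropyl. They also leave open what a longer chain at that place would give, and whether the configuration would count there.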